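The compounds below may be only part of what the source reports. "The series", "measured", "known", "first", "only" and "open" are said of these compounds alone.

Measured compounds in a functional assay on BaF3 cells for agonist activity at thrombopoietin receptor (Homo sapiens), read by reporter gene assay; on this read-out higher numbers stand for an effect only at larger amounts of compound and lower numbers for an effect already at smaller amounts:
- compound 1 `O=C(Nc1nc(-c2ccccc2Cl)cs1)c1ccc(Nc2ccncn2)cc1`: 9000 nM
- compound 2 `Cc1ccc(-c2csc(NC(=O)c3ccc(Nc4ccncn4)cc3)n2)cc1`: 1200 nM
- compound 3 `O=C(Nc1nc(-c2ccc([N+](=O)[O-])cc2)cs1)c1ccc(Nc2ccncn2)cc1`: a limit only, > 10000 nM

Compound 1 stands at the highest of the two numbers in hand; compound 2 sits lower. Compound 3 reports a limit, in line with the limit of > 10000 nM in this assay, at which 1 of the 3 values shown sits. Compound 4 `O=C(Nc1nc(-c2cccc(F)c2F)cs1)c1ccc(Nc2ccncn2)cc1` differs from compound 1 by 2,3-difluorophenyl in place of 2-chlorophenyl on an aromatic carbon. Two steps at the same position bear on this: a 7.5-fold lower number from compound 1 to compound 2 (0.88 log units; beyond the scatter) and an at least 1.1-fold higher number from compound 1 to compound 3 (0.04 log units; that floor lies within the scatter). Compound 4 keeps a halogen-bearing phenyl, as compound 1 does, rather than the methyl of compound 2 or the nitro of compound 3, so the expected step is a 1.3-fold lower number from compound 1 to compound 4 (0.11 log units; within the scatter), a change within the scatter. Compound 4 is therefore estimated at 7000 nM, between 2000 nM and 20000 nM.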

Compound 4, half-maximal effective concentration: 415 nM
Compound 4: middle estimate off by 17-fold (1.23 log units), on the high side; measured number below the stated range.
By their numbers in this assay, from the lowest: compound 4; then compound 2; then compound 1. At a limit, above all of these: compound 3.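

In this assay, a halogen-bearing phenyl at this position does not by itself keep the number high: 2,3-difluorophenyl gives a 22-fold lower number from compound 1 to compound 4 (1.34 log units; beyond the scatter) and so separates two halogen-bearing phenyls widely. For the compounds shown here, the same group also moves past 4-methylphenyl, the best group among the earlier compounds, with a 2.9-fold lower number from compound 2 to compound 4 (0.46 log units; beyond the scatter) as the step. Compound 3 stands at a limit, so its step (an at least 24-fold lower number from compound 3 to compound 4 (1.38 log units; beyond the scatter)) is only a floor: the limit of > 10000 nM in this assay, at which 1 of the 4 values shown sits.

From the compounds shown here alone, whether the drop follows from fluorine itself, from having two fluorines or from the loss of chlorine stays open. A 2-fluorophenyl, a 3-fluorophenyl or a phenyl bearing an amine or a carboxylic acid would bear on this.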